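The source may report more compounds than this note shows. Statements on the series, on what has been measured and on what is new or still open speak of the compounds shown alone.

Compound 1 `COc1ccc2nc(C)cc(OCC(=O)Nc3cc(C)cc(C)c3)c2c1` is the starting point of this piece. In an ADME assay on microsomes from liver (Homo sapiens) for metabolic stability, read by LC-MS, using NADPH, with a stated time of 30 min, tested at 0.5 uM (on this read-out lower numbers stand for a shorter-lived compound and higher numbers for a longer-lived compound), compound 1 gives > 0.5 h, which is a limit of the assay and not a number. Compound 2 `Cc1cc(C)cc(NC(=O)COc2cc(C)nc3ccc(C)cc23)c1` differs from it by methyl in place of methoxy on an aromatic carbon, and in this assay compound 2 gives > 0.5 h, again a limit. Compound 3 `COc1ccc2nc(C)cc(OCCNc3cc(C)cc(C)c3)c2c1` replaces the amide link with a plain chain, and in this assay compound 3 gives > 0.5 h, also a limit. Within the data shown here, the only step between measured compounds, a step that the two limits leave unreadable from compound 1 to compound 2, cannot be sized because both of its values sit at the limit of > 0.5 h in this assay, at which 3 of the 3 values shown sit.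

Compound 4 `COc1ccc2nc(C)cc(OCC(=O)Nc3cc(C)c(F)c(C)c3)c2c1` is the next compound, and it differs from compound 1 by fluoro in place of hydrogen on an aromatic carbon. Among the measured compounds shown here, no measured step touches this position, so the expectation rests only on the three values already seen, all of which sit at the same limit. Compound 4 is therefore expected to give 1 h in this assay, within a range of 0.4 h to 3 h. The step from compound 1 to compound 4 is estimated as a step that the limit leaves unreadable from compound 1 to compound 4, that is, no change beyond the scatter is expected.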

Compound 4, half-life: > 0.5 h
Compound 4 gave a limit, no number; the forecaster's own chance of this, stated with the estimate: 80%; the middle value is on the limit's open side.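

Compound 1 and compound 4 each give a limit and not a number, so no step can be read between them: the limit of > 0.5 h in this assay, at which 4 of the 4 values shown sit.

The compounds shown leave open whether the fluoro group, the methyl in place of methoxy or the plain chain changes the half-life at all.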